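Same atoms joined differently: from compound 2 to compound 3

This account rests on a few compounds, and the source may have more. Where it says the series, first, only, none or still open, it means among the compounds named here.

In a functional assay on L1210 cells (Mus musculus) for inhibition (a lower number here means a stronger inhibitor, a higher number a weaker inhibitor), compound 1 (`CC(C)CN(CC(=O)N(CC(C)C)NC(=O)OCc1ccccc1)/N=C/c1ccccc1B(O)O`) gives 16200 nM and compound 2 (`CC(C)CN(CC(=O)N(Cc1ccccc1)NC(=O)OCc1ccccc1)/N=C/c1ccccc1B(O)O`) gives 18400 nM as its reading. Among the compounds with values here, the one measured step is a 1.1-fold higher number from compound 1 to compound 2 (0.06 log units; within the scatter) and it leaves compound 2 level with compound 1 within the scatter. Compound 3 (`CC(C)CN(CC(=O)N(Cc1ccccc1)NC(=O)OCc1ccccc1)/N=C/c1cccc(B(O)O)c1`) has the same atoms as compound 2, joined differently. The change is a group of 9 heavy atoms (6 carbon, 1 boron, 2 oxygen; one six-membered aromatic ring of carbon only) in place of a group of 9 heavy atoms (6 carbon, 1 boron, 2 oxygen; one six-membered aromatic ring of carbon only), on a carbon with a double bond to nitrogen and it sits on a carbon with a double bond to nitrogen. The measured step concerns another place, a saturated chain carbon bound to an amide-type nitrogen, and it offers no direct guide to this change. Within the data shown here, no measured pair tests a change on the carbon with a double bond to nitrogen, and the data show no direction for it. The natural anchor is compound 2 with 18400 nM as its value, held with wide uncertainty. The expected size of the change is a 1.1-fold higher number from compound 2 to compound 3 (0.04 log units; within the scatter) and no shift beyond the scatter is expected. The estimated value in this assay for compound 3 is 20000 nM with an expected range from 7000 nM to 55000 nM for that compound.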

Compound 3, half-maximal inhibitory concentration: 16900 nM
Estimate against measurement, compound 3: 1.2-fold (0.07 log units) above; low and high end bracket the measured number.
By their numbers in this assay, from the lowest: compounds 1, 3 and 2 (each within the scatter of the next).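

In this assay, the step is a 1.1-fold lower number from compound 2 to compound 3 (0.04 log units; within the scatter), so joining the same atoms differently in the group on a carbon with a double bond to nitrogen leaves the reading within the scatter. Within the data shown here, this is the first pair to test that place, since the earlier step concerned a saturated chain carbon bound to an amide-type nitrogen, and it shows that this rearrangement, which keeps the group's one six-membered aromatic ring of carbon only and its boron and oxygen atoms, does not separate compound 2 from compound 3 in this cell assay. No information at hand bears on why the reading holds, and the result gives no account of how these compounds act.

The compounds shown leave open whether this place responds at all to a change in the atoms themselves, as they would with a carboxylic acid taking the place of the boron-bearing part of the group. They also leave open whether a longer chain on the saturated chain carbon would move the number beyond the scatter, given that the only two changes shown so far both stay within it.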